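Nitro to amino on two related cores: matched steps

This account rests on a few compounds, and the source may have more. Where it says the series, first, only, none or still open, it means among the compounds named here.

Measured so far:
Compound 1 `COc1ccc(-c2ssc(=O)c2-c2cc(OC)c(OC)c(OC)c2)cc1[N+](=O)[O-]`: in a functional assay on KB cells (Homo sapiens) for antiproliferative activity, read by MTT assay, with a stated time of 72 h (on this read-out higher numbers stand for weaker inhibition and lower numbers for stronger inhibition), compound 1 gives 22300 nM.
Compound 2 `COc1ccc(-c2ssc(=O)c2-c2cc(OC)c(OC)c(OC)c2)cc1N`: in this assay compound 2 gives 60 nM.
Compound 3 `COc1ccc(-c2c(-c3cc(OC)c(OC)c(OC)c3)ss/c2=N/O)cc1[N+](=O)[O-]`: in this assay compound 3 gives 5260 nM.

Among the compounds with values here, only one pair of measured compounds differs in a single place. The change is amino in place of nitro on an aromatic carbon, and the step it made is a 370-fold lower number from compound 1 to compound 2 (2.57 log units; beyond the scatter). Compound 3 carries a core that is not the core of compound 1; the difference between the two cores is not broken down here. What the values show is that compound 3 stands second highest of the three, nearer to compound 1 than to compound 2, and beyond the scatter from both.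

Compound 4 `COc1ccc(-c2c(-c3cc(OC)c(OC)c(OC)c3)ss/c2=N/O)cc1N` has not been measured. It differs from compound 3 by amino in place of nitro on an aromatic carbon. The group that leaves, the group that enters and the surroundings of the place are the same as in the change from compound 1 to compound 2, so this is the same change made on the core of compound 3.

Within the data shown here, for compound 4 the step from compound 3 in this assay is expected to be a 210-fold lower number from compound 3 to compound 4 (2.32 log units; beyond the scatter), resting on the single earlier instance of this change, a 370-fold lower number from compound 1 to compound 2 (2.57 log units; beyond the scatter). Among the measured compounds shown here, with only one prior instance, the size is expected to be of the same order but not necessarily the same. On this basis compound 4 is estimated at 25 nM, expected between 6 nM and 120 nM.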

Compound 4, half-maximal inhibitory concentration: 2910 nM
Beside the measured number, compound 4's estimate is 120-fold (2.07 log units) below it; the whole stated range lies below it.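

In this assay, amino in place of nitro on an aromatic carbon gives a 1.8-fold lower number from compound 3 to compound 4 (0.26 log units; within the scatter), so the large step seen on the core of compound 1 does not reappear on the core of compound 3. The two steps set side by side show that the size of this change depends on the core in these two pairs: the same change on two cores in this assay, a 370-fold lower number (2.57 log units; beyond the scatter) from compound 1 to compound 2 and a 1.8-fold lower number (0.26 log units; within the scatter) from compound 3 to compound 4, 210-fold (2.31 log units) apart, beyond the scatter of two such steps. This does not show why the cores part ways, and two pairs give no rule for any other core, so neither step can be taken as the expected size of this change elsewhere in the series.

Still open, on these data alone, is whether other groups at this place, such as a hydroxyl, a methylamino or an acetamido group, would give large steps on the core of compound 1 and small ones on the core of compound 3, or would behave alike on both. Also open, as far as these compounds go, is whether the difference between the two cores would persist with an ethoxy group in place of the methoxy group that the amino group sits ortho to.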